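Changing the Aryl Group on a Shared Core

A few compounds are considered here, and "the series" means these few. Any claim that something is new, unique, unknown or untested is made for them only; others in the source may bear on it.

Compound 3 `COc1ccc(F)cc1-c1cccc2nc(Nc3cc(OC)c(OC)c(OC)c3)oc12` gives 3700 nM in an assay on BAF cells for inhibition of ribosomal protein S6 kinase alpha-2 (Mus musculus) (on this read-out lower numbers stand for stronger inhibition and higher numbers for weaker inhibition), which places it second highest of the three measured compounds: compound 1 `COc1cc(Nc2nc3cccc(-c4c(F)cccc4OC)c3o2)cc(OC)c1OC` gives 2600 nM, and compound 2 `CCOc1cccc(F)c1-c1cccc2nc(Nc3cc(OC)c(OC)c(OC)c3)oc12` gives 10800 nM. Compound 4 `COc1cc(Nc2nc3cccc(-c4ccccc4-c4cn[nH]c4)c3o2)cc(OC)c1OC` differs from compound 3 in a group of 11 heavy atoms (9 carbon, 2 nitrogen; one five-membered aromatic ring with 2 hetero atoms, one six-membered aromatic ring of carbon only) in place of a group of 9 heavy atoms (7 carbon, 1 oxygen, 1 fluorine; one six-membered aromatic ring of carbon only), on an aromatic carbon. For the measured compounds named here, two measured steps concern exchanges of the same aryl group: a 1.4-fold higher number from compound 1 to compound 3 (0.15 log units; within the scatter) and a 2.9-fold lower number from compound 2 to compound 3 (0.47 log units; beyond the scatter). A third step, a 4.2-fold higher number from compound 1 to compound 2 (0.62 log units; beyond the scatter), altered only a chain on that aryl group. The group entering in compound 4 departs further from those measured, so these steps give only a loose guide, and a change of modest size in either direction seems plausible. Compound 4 is therefore expected to give 2500 nM, within 600 nM to 10000 nM, corresponding to a 1.5-fold lower number from compound 3 to compound 4 (0.17 log units; within the scatter).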

Compound 4, half-maximal inhibitory concentration: > 20000 nM
Compound 4: only a limit was reported; the forecaster's own chance of this, stated with the estimate: 5%; at least 8.0-fold (0.90 log units) between middle value and limit.
By their numbers in this assay, from the lowest: compounds 1 and 3 (each within the scatter of the next); then compound 2. At a limit, above all of these: compound 4.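

For compound 4 only a limit was reported: the limit of > 20000 nM in this assay, at which 1 of the 4 values shown sits.

The new group at this aromatic carbon gives an at least 5.4-fold higher number from compound 3 to compound 4 (0.73 log units; beyond the scatter) and an at least 7.6-fold higher number from compound 1 to compound 4 (0.88 log units; beyond the scatter), so this position does not accept every aryl exchange with the small shifts seen between compound 1 and compound 3. Against the ethoxy analogue, an at least 1.8-fold higher number from compound 2 to compound 4 (0.26 log units; that floor lies within the scatter) has a floor within the scatter, so compound 4 cannot yet be separated from compound 2.

The compounds shown leave open whether the five-membered aromatic ring or the second six-membered ring accounts for the weaker result. On these data alone, a plain phenyl or a phenyl bearing a carboxylic acid at this position remains untested among them.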